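From a hexynyl chain to 4-fluorophenyl

A few compounds are considered here, and "the series" means these few. Any claim that something is new, unique, unknown or untested is made for them only; others in the source may bear on it.

Among the measured compounds shown here, in a functional assay on HL-60 cells (Homo sapiens) for antiproliferative activity, with a stated time of 72 h (a higher number here means a weaker inhibitor, a lower number a stronger inhibitor), compound 1 `CCCCC#Cc1cc([C@@H]2O[C@H](CO)[C@@H](O)[C@H]2O)n2ncnc(N)c12` gives 400 nM, the only actual number in this small series. Compound 2 `Nc1ncnn2c([C@@H]3O[C@H](CO)[C@@H](O)[C@H]3O)cc(C#Cc3cccs3)c12` reads > 100000 nM, which is a limit. Compound 3 `Nc1ncnn2c([C@@H]3O[C@H](CO)[C@@H](O)[C@H]3O)cc(C#Cc3ccccc3)c12` reads > 100000 nM, also a limit.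

Compound 4 `Nc1ncnn2c([C@@H]3O[C@H](CO)[C@@H](O)[C@H]3O)cc(-c3ccc(F)cc3)c12` is not yet measured. It has 4-fluorophenyl in place of hex-1-yn-1-yl on an aromatic carbon. The nearest measured changes also replace butyl with an aromatic ring, but they keep the triple bond. They are an at least 250-fold higher number from compound 1 to compound 2 (2.39 log units; beyond the scatter) and an at least 250-fold higher number from compound 1 to compound 3 (2.39 log units; beyond the scatter), both large. On these two steps, a large move to a higher number is expected, with the expected step being a 50-fold higher number from compound 1 to compound 4 (1.70 log units; beyond the scatter). Compound 4 is estimated at 20000 nM, within an expected range of 2500 nM to 100000 nM.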

Compound 4, half-maximal inhibitory concentration: 68300 nM
Beside the measured number, compound 4's estimate is 3.4-fold (0.53 log units) below it, within the range that was stated.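

A 4-fluorophenyl group set directly on this aromatic carbon, with no triple bond, also loses most of the activity: a 170-fold higher number from compound 1 to compound 4 (2.23 log units; beyond the scatter). Against the aromatic alkynes the readings are an at least 1.4-fold lower number from compound 3 to compound 4 (0.16 log units; that floor lies within the scatter) and an at least 1.4-fold lower number from compound 2 to compound 4 (0.16 log units; that floor lies within the scatter), so removing the triple bond shows no readable gain. Both of those comparisons rest on limits rather than numbers: the limit of > 100000 nM in this assay, at which 2 of the 4 values shown sit.

As far as these compounds go, whether the triple bond or the butyl chain carries the activity of compound 1 stays open. A saturated hexyl chain, or a longer chain on the triple bond, would separate the two.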